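A Second Hydroxy Group on the Aryl Ring

This account rests on a few compounds, and the source may have more. Where it says the series, first, only, none or still open, it means among the compounds named here.

Of the compounds shown here, three have been measured in a functional assay on PC-3 cells (Homo sapiens) for inhibition, read by sulforhodamine B assay, with a stated time of 48 h; a lower number here means a stronger inhibitor of growth, a higher number a weaker inhibitor of growth. Compound 2 `CCOC(=O)C1=C(C)NC(=S)NC1C1CCCCC1` gives 0.46 ug/mL, compound 1 `CCOC(=O)C1=C(C)NC(=O)NC1c1ccc(SC)cc1` gives 9.5 ug/mL, and compound 3 `CCOC(=O)C1=C(C)NC(=S)NC1c1ccc(O)cc1` gives 47.6 ug/mL, the highest number of the three, well above the other two. Compound 4 `CCOC(=O)C1=C(C)NC(=S)NC1c1ccc(O)c(O)c1` differs from compound 3 by hydroxy in place of hydrogen on an aromatic carbon. Going by the values given here, no measured pair shows the effect of such a change, so nothing in the data points to a direction; the expectation is a step from compound 3 to compound 4 of no size beyond the scatter of this assay. Compound 4 is therefore expected to give about 45 ug/mL, within a range of 12 ug/mL to 160 ug/mL. The estimated step is a 1.1-fold lower number from compound 3 to compound 4 (0.02 log units; within the scatter).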

Compound 4, concentration for 50% growth inhibition: 25 ug/mL
For compound 4 the middle estimate is 1.8-fold (0.26 log units) above the measured one, within the range that was stated.
By their numbers in this assay, from the lowest: compound 2; then compound 1; then compounds 4 and 3 (each within the scatter of the next).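

Hydroxy in place of hydrogen on an aromatic carbon, ortho to a hydroxy group, gives a 1.9-fold lower number from compound 3 to compound 4 (0.28 log units; within the scatter) and so provides the first reading of this change, which no earlier pair offered. At this position, the added hydroxy group leaves compound 3 and compound 4 without an order in this assay. No evidence at hand bears on this result. Still open, on these data alone, is whether a methoxy group or an amine at the same place would give a step beyond the scatter, and whether hydroxy would give the same step on another core.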